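Methyl on the Distal Phenyl Ring of Compound 1

A few compounds are considered here, and "the series" means these few. Any claim that something is new, unique, unknown or untested is made for them only; others in the source may bear on it.

Measured so far:
Compound 1, `CCc1cc2ccccc2nc1-c1cc(-c2ccccc2)no1`: in a functional assay on A549 cells (Homo sapiens) for inhibition, read by MTT assay, with a stated time of 24 h (a higher number here means a weaker inhibitor, a lower number a stronger inhibitor), compound 1 gives > 100000 nM, a limit of the assay.
Compound 2, `CCCCc1cc2ccccc2nc1-c1cc(-c2ccccc2)no1`: in this assay compound 2 gives > 100000 nM, also a limit of the assay.
Compound 3, `CCCCCc1cc2ccccc2nc1-c1cc(-c2ccccc2)no1`: in this assay compound 3 gives 92300 nM.

Compound 1 stands at a limit of this assay, so its value is a bound and not a number, and (the limit of > 100000 nM in this assay, at which 2 of the 3 values shown sit). Compound 4, `CCc1cc2ccccc2nc1-c1cc(-c2ccc(C)cc2)no1`, differs from compound 1 by methyl in place of hydrogen on an aromatic carbon. Going by the values given here, none of the measured steps touches that ring; all of them alter the saturated chain on the shared core. The step that the two limits leave unreadable from compound 1 to compound 2. The steps of an at least 1.0-fold lower number from compound 1 to compound 3 (0.03 log units; that floor lies within the scatter) and an at least 1.0-fold lower number from compound 2 to compound 3 (0.03 log units; that floor lies within the scatter). Among the compounds with values here, these three steps therefore carry no information about a methyl on the phenyl ring, and they show only that the chain changes tried leave the numbers at or near the limit. Within the data shown here, with no measured step bearing on the change, the expectation for compound 4 in this assay is no step beyond the scatter, that is a number no higher from compound 1 to compound 4 (the limit leaves the size open), and most likely a limit once more. Compound 4 is accordingly estimated at 100000 nM in this assay, between 50000 nM and 300000 nM.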

Compound 4, half-maximal inhibitory concentration: > 100000 nM
Compound 4 ended at the assay's limit; the forecaster's own chance of this, stated with the estimate: 70%; the middle value sits exactly at the limit.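

In this assay compound 4 gives > 100000 nM, a limit of the assay. Compound 1 gives > 100000 nM, also a limit, so the step from compound 1 to compound 4 cannot be read. The compounds shown leave open whether the change from phenyl to 4-methylphenyl moves the number in either direction, and by how much.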